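The source may hold more compounds than are shown below. What is called first, only, known or untested is meant among the compounds shown, and "the series" means these compounds.

Values in a functional assay on A549 cells (Homo sapiens) for cytotoxicity, read by sulforhodamine B assay, with a stated time of 72 h; on this read-out higher numbers stand for weaker inhibition and lower numbers for stronger inhibition:

compound 1, `CCS(=O)(=O)Nc1cc(-c2ccc3ncnc(Nc4ccc(F)cc4)c3c2)cnc1OC`: 7620 nM
compound 2, `CCS(=O)(=O)Nc1cc(-c2ccc3ncnc(Nc4ccc(F)cc4F)c3c2)cnc1OC`: 4710 nM
compound 3, `CCS(=O)(=O)Nc1cc(-c2ccc3ncnc(Nc4cccc(C(=O)OC)c4)c3c2)cnc1OC`: 1100 nM

The change from compound 1 to compound 2 is fluoro in place of hydrogen on an aromatic carbon; it gave a 1.6-fold lower number from compound 1 to compound 2 (0.21 log units; within the scatter). The cores of compound 1 and compound 3 differ by 3-(methoxycarbonyl)phenyl in place of 4-fluorophenyl on a nitrogen on an aromatic ring, which gave a 6.9-fold lower number from compound 1 to compound 3 (0.84 log units; beyond the scatter), and likewise a 4.3-fold lower number from compound 2 to compound 3 (0.63 log units; beyond the scatter).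

Compound 4, `CCS(=O)(=O)Nc1cc(-c2ccc3ncnc(Nc4ccc(F)c(C(=O)OC)c4)c3c2)cnc1OC`, differs from compound 3 by fluoro in place of hydrogen on an aromatic carbon. This is the same kind of change as from compound 1 to compound 2, but the surroundings differ: in compound 2 the entering fluoro is ortho to a large group and meta to a fluoro group, whereas in compound 4 it is ortho to a methoxycarbonyl group (4 heavy atoms) and para to a large group. A small step is expected from compound 3 to compound 4 in this assay, about a 1.4-fold lower number from compound 3 to compound 4 (0.14 log units; within the scatter), because the matching step a 1.6-fold lower number from compound 1 to compound 2 (0.21 log units; within the scatter) lay within the scatter. Compound 4 is therefore estimated at 800 nM, with a likely range of 300 nM to 2500 nM.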

Compound 4, half-maximal inhibitory concentration: 3420 nM
Estimate against measurement, compound 4: 4.3-fold (0.63 log units) below; measured number outside the range, above it.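

In this assay, fluoro in place of hydrogen on an aromatic carbon does not carry over unchanged from one core to another, and the two steps differ: the same change on two cores in this assay, a 1.6-fold lower number (0.21 log units; within the scatter) from compound 1 to compound 2 and a 3.1-fold higher number (0.49 log units; beyond the scatter) from compound 3 to compound 4, 5.0-fold (0.70 log units) apart, beyond the scatter of two such steps. With the fluoro already on the ring, methoxycarbonyl in place of hydrogen still gives a 2.2-fold lower number from compound 1 to compound 4 (0.35 log units; beyond the scatter), compared with a 3.1-fold higher number from compound 3 to compound 4 (0.49 log units; beyond the scatter) for adding fluoro to the methoxycarbonyl ring, while the swap from 2,4-difluorophenyl gives a 1.4-fold lower number from compound 2 to compound 4 (0.14 log units; within the scatter). With one pair on each core, this shows that the fluoro step on one core does not predict the step on the other, but not what in the surroundings sets the difference.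

Left open is whether the fluoro step on compound 3 behaves the same way when methoxycarbonyl is exchanged for a carboxylic acid or a primary amide.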